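The source may hold more compounds than are shown below. What is called first, only, known or untested is meant among the compounds shown, and "the series" means these compounds.

Two compounds of this series have been run in a functional assay on PC-3 cells (Homo sapiens) for cytotoxicity, read by sulforhodamine B assay, with a stated time of 72 h; a higher number here means a weaker inhibitor of growth, a lower number a stronger inhibitor of growth. Compound 1 `O=C(Nc1cc(C(F)(F)F)cc(C(F)(F)F)c1)C1CCc2ccccc2N1C(=O)c1ccccc1Cl` gives 8040 nM. Among the measured compounds shown here, compound 2 `CCC(=O)N1c2ccccc2CCC1C(=O)Nc1cc(C(F)(F)F)cc(C(F)(F)F)c1` gives 8540 nM; among the two numbers so far, compound 2 gives the higher one, though its only neighbour is compound 1, which stands a 1.1-fold higher number from compound 1 to compound 2 (0.03 log units; within the scatter), so the two are indistinguishable within the scatter. Compound 3 `O=C(Nc1cc(C(F)(F)F)cc(C(F)(F)F)c1)C1CCc2ccccc2N1C(=O)c1cccc(Cl)c1` has not yet been measured; it differs from compound 2 by 3-chlorophenyl in place of ethyl on a carbonyl carbon. For the measured compounds named here, the single step that bears on this change is the one from compound 1 to compound 2, which replaced 2-chlorophenyl on the carbonyl carbon by ethyl and produced a shift of a 1.1-fold higher number from compound 1 to compound 2 (0.03 log units; within the scatter). Swapping between an aryl and an ethyl group on that carbonyl carbon thus left this assay unmoved, and on that basis the return to a chlorophenyl is expected to move compound 3 by a 1.1-fold lower number from compound 2 to compound 3 (0.03 log units; within the scatter), no more than scatter. Compound 3 is therefore estimated at 8000 nM, with a range of 3000 nM to 20000 nM.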

Compound 3, concentration for 50% growth inhibition: 1050 nM
Compound 3: middle estimate off by 7.6-fold (0.88 log units), on the high side; measured number below the stated range.
By their numbers in this assay, from the lowest: compound 3; then compounds 1 and 2 (each within the scatter of the next).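

In this assay the carbonyl carbon on the amide-type ring nitrogen proves sensitive to its substituent, which the ethyl and 2-chlorophenyl pair had not revealed. The step of an 8.1-fold lower number from compound 2 to compound 3 (0.91 log units; beyond the scatter) comes with 3-chlorophenyl in place of ethyl, so this aryl group separates from ethyl where 2-chlorophenyl did not. The step of a 7.7-fold lower number from compound 1 to compound 3 (0.88 log units; beyond the scatter) shows that a chlorophenyl ring alone does not account for the gain, since the two isomeric groups give clearly different numbers on the same core.

Still open, going by these compounds, is whether the chlorine is needed at all, which an unsubstituted phenyl would test, and whether a fluorine, a methoxy group or a nitrile could take its place. Nothing available explains why the two chlorophenyl groups differ.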